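The source may report more compounds than this note shows. Statements on the series, on what has been measured and on what is new or still open speak of the compounds shown alone.

In a functional assay on MCF7 cells (Homo sapiens) for antiproliferative activity, read by MTT assay, with a stated time of 48 h (on this read-out lower numbers stand for stronger inhibition and higher numbers for weaker inhibition), compound 1 (`CC(=O)N1N=C(c2ccc3ccccc3c2)OC1c1ccccc1`) gives 2.43 ug/mL, compound 2 (`CC(=O)N1N=C(c2ccc3ccccc3c2)OC1c1ccc(Cl)cc1`) gives 2.63 ug/mL and compound 3 (`CC(=O)N1N=C(c2ccc3ccccc3c2)OC1c1ccc(F)cc1`) gives 3.02 ug/mL. Compound 3 stands within the scatter of both others: a 1.2-fold higher number from compound 1 to compound 3 (0.09 log units; within the scatter) and a 1.1-fold higher number from compound 2 to compound 3 (0.06 log units; within the scatter). Compound 4 (`CC(=O)N1N=C(c2ccc3ccccc3c2)OC1c1ccc(C)cc1`) differs from compound 3 as follows: methyl in place of fluoro on an aromatic carbon. This is methyl in place of fluoro on an aromatic carbon, para to a large group. Within the data shown here, no measured compound carries methyl, so the closest evidence is the other exchanges at this carbon, a 1.1-fold higher number from compound 1 to compound 2 (0.03 log units; within the scatter) alongside the two above, all within the scatter. No step beyond the scatter is therefore expected in this assay. The expected step is small: a 1.1-fold lower number from compound 3 to compound 4 (0.05 log units; within the scatter). The estimated value for compound 4 is 2.7 ug/mL, with an expected range of 1.4 ug/mL to 5.2 ug/mL.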

Compound 4, half-maximal inhibitory concentration: 2.9 ug/mL
Estimate against measurement, compound 4: 1.1-fold (0.03 log units) below, within the range that was stated.
By their numbers in this assay, from the lowest: compounds 1, 2, 4 and 3 (each within the scatter of the next).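

Methyl is the first carbon group at this aromatic carbon, and in this assay it stays within the scatter of fluoro (a 1.0-fold lower number from compound 3 to compound 4 (0.02 log units; within the scatter)), chloro (a 1.1-fold higher number from compound 2 to compound 4 (0.04 log units; within the scatter)) and hydrogen (a 1.2-fold higher number from compound 1 to compound 4 (0.08 log units; within the scatter)). Across compounds 1 to 4, these four exchanges on the phenyl ring therefore leave the read-out unresolved, with no exception among them. No measured evidence bears on this result.

From the compounds shown here alone, whether an amine, a carboxylic acid or a longer chain at this carbon would step beyond the scatter remains open. Changes elsewhere on the shared core also remain open.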